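A Large Aryl Group Replaces Methoxy

The source may report more compounds than this note shows. Statements on the series, on what has been measured and on what is new or still open speak of the compounds shown alone.

In a functional assay on the whole organism with Rattus norvegicus as the target (a higher number here means that more compound is needed for the effect, a lower number that less compound is needed), compound 1 `CCOC(=O)C(=O)Nc1nc(-c2cc(Br)no2)cs1` gives 12 mg/kg, while compound 2 `CCOCCOC(=O)C(=O)Nc1nc(-c2cc(OC)no2)cs1` gives 3 mg/kg, the lower of the two numbers by a margin beyond the usual scatter. Compound 3 `CCOCCOC(=O)C(=O)Nc1nc(-c2cc(-c3c(F)cccc3Cl)no2)cs1` carries 2-chloro-6-fluorophenyl in place of methoxy on an aromatic carbon. Going by the values given here, no measured pair here shows a single change on its own, so this forecast is uncertain. A modest upward step, meaning more compound needed, is expected, and the estimate is a 1.7-fold higher number from compound 2 to compound 3 (0.22 log units; within the scatter). Compound 3 is expected at about 5 mg/kg, with an estimated range of 1 mg/kg to 20 mg/kg.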

Compound 3, dose for half-maximal effect: 1.1 mg/kg
For compound 3 the middle estimate is 4.5-fold (0.66 log units) above the measured one, and the stated range covers the measured number.
By their numbers in this assay, from the lowest: compound 3; then compound 2; then compound 1.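

In this assay, going by these compounds alone, placing 2-chloro-6-fluorophenyl in place of methoxy gives a 2.7-fold lower number from compound 2 to compound 3 (0.44 log units; beyond the scatter) and is the first single change that can be read in this set. It shows that this aromatic carbon, next to the ring nitrogen, tolerates a six-membered aromatic ring of 8 heavy atoms in place of a group of 2, and that less compound is then needed. Nothing measured here explains the step. As far as these compounds go, whether the gain needs the chlorine and fluorine, or the ring alone suffices, stays open. Plain phenyl or an amine at this carbon would help separate those possibilities.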